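The source may hold more compounds than are shown below. What is called first, only, known or untested is meant among the compounds shown, and "the series" means these compounds.

Compound 1, `O=C1C=CC(OCC(F)(F)F)N1c1cc(Cl)cc(Cl)c1`: 5920 nM
Compound 2, `Cc1ccc(N2C(=O)C=CC2OCC(F)(F)F)cc1`: 9380 nM
Compound 3, `CCc1ccc(N2C(=O)C=CC2OCC(F)(F)F)cc1`: 6510 nM

In a functional assay on HeLa cells (Homo sapiens) for inhibition (on this read-out higher numbers stand for weaker inhibition and lower numbers for stronger inhibition), compound 3 gives 6510 nM, the second highest of the three numbers; its gaps to compound 1 and to compound 2 both lie within the scatter, so no order among the three can be read from them. Compound 4 is `COC(=O)c1ccc(N2C(=O)C=CC2OCC(F)(F)F)cc1`. It differs from compound 3 by methoxycarbonyl in place of ethyl on an aromatic carbon. For the measured compounds named here, the only measured step at this part of the molecule is a 1.4-fold lower number from compound 2 to compound 3 (0.16 log units; within the scatter), an exchange of one short chain for another that stayed within the scatter. No measured step exchanges a chain for a methoxycarbonyl group, so nothing among these compounds shows how such a change acts, and the three numbers all sit close together. The step from compound 3 to compound 4 in this assay is therefore expected to be small, a 1.1-fold higher number from compound 3 to compound 4 (0.03 log units; within the scatter), with a wide margin in either direction. Compound 4 is expected to give about 7000 nM, between 2500 nM and 20000 nM.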

Compound 4, half-maximal inhibitory concentration: 5700 nM
Beside the measured number, compound 4's estimate is 1.2-fold (0.09 log units) above it; low and high end bracket the measured number.
By their numbers in this assay, from the lowest: compounds 4, 1, 3 and 2 (each within the scatter of the next).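

Compounds 2 and 3 carry only a short carbon chain on this aromatic carbon, para to a large group, so they could not show what a group with hydrogen-bond acceptors does there. In this assay methoxycarbonyl, with its two hydrogen-bond acceptors and larger count of heavy atoms, gives a 1.1-fold lower number from compound 3 to compound 4 (0.06 log units; within the scatter) and a 1.6-fold lower number from compound 2 to compound 4 (0.22 log units; within the scatter), so neither exchange moves the number beyond the usual scatter of this assay. No measurement at hand explains why the number stays put here.

As far as these compounds go, whether any group at this position can move the number beyond the scatter remains open, for example an amine, a carboxylic acid or a longer chain. Also open, from the compounds shown here alone, is whether the methoxycarbonyl group would behave the same way on another carbon of the aromatic ring.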